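Swapping a pyridinylmethyl amide for a hexyl chain

The compounds below may be only part of what the source reports. "The series", "measured", "known", "first", "only" and "open" are said of these compounds alone.

Compound 1 `COc1cc(-c2cc(C(=O)O)c3ccccc3n2)ccc1OCC(=O)Nc1ccccc1F` in an ADME assay on HaCaT cells (Homo sapiens) for inhibition (on this read-out higher numbers stand for weaker inhibition and lower numbers for stronger inhibition), gives 161000 nM. Going by these compounds, compound 2 `COc1cc(-c2cc(C(=O)O)c3ccccc3n2)ccc1OCC(=O)NCc1cccnc1` reaches only a limit in this assay, reported as > 300000 nM, so its true value stays unknown. The step of an at least 1.8-fold higher number from compound 1 to compound 2 (0.27 log units; that floor lies within the scatter) therefore has a floor but no ceiling. Compound 3 `CCCCCCNC(=O)COc1ccc(-c2cc(C(=O)O)c3ccccc3n2)cc1OC` differs from compound 2 by pentyl in place of pyridin-3-yl on a saturated chain carbon bound to an amide-type nitrogen. Among the measured compounds shown here, only one measured step bears on this change, and it runs into the limit (the limit of > 300000 nM in this assay, at which 1 of the 2 values shown sits), so no direction can be read from it. Compound 3 is expected to stay at a similarly weak level, with an at least 1.2-fold lower number from compound 2 to compound 3 (0.07 log units; that floor lies within the scatter) as the expected step. Compound 3 is estimated at 250000 nM, within 100000 nM to 600000 nM.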

Compound 3, half-maximal inhibitory concentration: > 300000 nM
Compound 3 ended at the assay's limit; the forecaster's own chance of this, stated with the estimate: 45%; at least 1.2-fold (0.07 log units) between middle value and limit.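

In this assay compound 3 gives > 300000 nM and this is a limit of the assay, so a hexyl chain without a ring on the amide nitrogen ends at the same limit as the (pyridin-3-yl)methyl group of compound 2. Set against the 2-fluorophenyl amide, the change to hexyl gives an at least 1.8-fold higher number from compound 1 to compound 3 (0.27 log units; that floor lies within the scatter) and has no ceiling. The step between compound 2 and compound 3 cannot be read, because both sit at the limit: the limit of > 300000 nM in this assay, at which 2 of the 3 values shown sit.

Going by these compounds, whether a shorter butyl chain, or a chain ending in an amine, would give a real number stays open.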